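Removing the small selenium group from compound 3

The compounds below may be only part of what the source reports. "The series", "measured", "known", "first", "only" and "open" are said of these compounds alone.

Measured so far in a functional assay on A549 cells (Homo sapiens) for inhibition, read by MTT assay, with a stated time of 48 h; a higher number here means a weaker inhibitor, a lower number a stronger inhibitor:
compound 1 `COc1ccc(N(C)c2nc(C)nc3ccccc23)cc1OCCC[Se]C#N` gives 382 nM
compound 2 `Cc1nc(N(C)c2ccc([Se]C#N)c(C)c2)c2ccccc2n1` gives 8 nM
compound 3 `COc1ccc(N(C)c2nc(C)nc3ccccc23)cc1[Se]C` gives 11 nM

Compound 3 stands at the low end of these numbers, and a low number means a stronger inhibitor. Its value of 11 nM lies within the usual scatter of repeated measurements of that of compound 2, so the two cannot be told apart. Compound 1 lies far from both.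

The next structure is compound 4 `COc1ccc(N(C)c2nc(C)nc3ccccc23)cc1`. The change is a hydrogen atom in place of a group of 2 heavy atoms (1 carbon, 1 selenium; no ring), on an aromatic carbon, ortho to a methoxy group (2 heavy atoms) and meta to a large group.

For the measured compounds named here, one measured step bears on this carbon. It is large and beyond the scatter: a 35-fold lower number from compound 1 to compound 3 (1.54 log units; beyond the scatter). There, a group of 7 heavy atoms gave way to a group of 2 heavy atoms. Going by the values given here, that step points towards lower numbers as the group shrinks, but no measured compound shows what bare hydrogen does here. A much smaller step is therefore expected in this assay, probably within the scatter and leaning slightly lower. The estimated change is a 1.6-fold lower number from compound 3 to compound 4 (0.20 log units; within the scatter). For compound 4 the estimated value is 7 nM, with an expected range of 2 nM to 30 nM.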

Compound 4, half-maximal inhibitory concentration: 3 nM
The estimate for compound 4 lay 2.3-fold (0.37 log units) above the measured number; measured number inside the range.
By their numbers in this assay, from the lowest: compound 4; then compounds 2 and 3 (each within the scatter of the next); then compound 1.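

On this aromatic carbon, a selenium group is not needed for a low number: replacing the small selenium group with hydrogen gives a 3.7-fold lower number from compound 3 to compound 4 (0.56 log units; beyond the scatter) in this assay and this step, though modest, lies beyond the scatter. Hydrogen in place of the longer selenium chain gives a 130-fold lower number from compound 1 to compound 4 (2.10 log units; beyond the scatter) so across these three compounds the number falls at each reduction in size, from the group of 7 heavy atoms through the group of 2 heavy atoms to no heavy atom at all, and none of the three goes against this order. No measurement available here explains this order.

Going by these compounds, three compounds make a short series, and size and selenium change together in it, so the contribution of selenium itself remains open. A methyl or ethyl group on this carbon would separate the two, matching the size of a selenium group without the selenium, while a hydroxyl group or an amine would show whether other small groups can match the number seen with bare hydrogen.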